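Azetidine ethers: acetamidomethyl replacing trifluoromethyl

The compounds below may be only part of what the source reports. "The series", "measured", "known", "first", "only" and "open" are said of these compounds alone.

Three analogues on a shared core have numbers in an assay on brain for binding affinity to Neuronal acetylcholine receptor; alpha4/beta2 (Rattus norvegicus), read by radioligand binding; on this read-out lower numbers stand for stronger inhibition and higher numbers for weaker inhibition. Within the data shown here, compound 1 `Fc1ccc(OC[C@@H]2CCN2)cn1` gives 0.057 nM and compound 2 `CCc1ccc(OC[C@@H]2CCN2)cn1` gives 19 nM; the single recorded step, a 330-fold higher number from compound 1 to compound 2 (2.52 log units; beyond the scatter), is large. Compound 3 `FC(F)(F)c1cncc(OC[C@@H]2CCN2)c1` gives 0.49 nM, the second highest of the three numbers, nearest to compound 1 and furthest from compound 2. The change to compound 4 `CC(=O)NCc1cncc(OC[C@@H]2CCN2)c1` is acetamidomethyl in place of trifluoromethyl on an aromatic carbon. Among the measured compounds shown here, no measured step covers this exchange; the only step, a 330-fold higher number from compound 1 to compound 2 (2.52 log units; beyond the scatter), swaps fluoro for ethyl and bears on it indirectly, as the one case where a group of more heavy atoms enters an aromatic carbon and the number rises. A rise beyond the scatter is therefore expected, though smaller. Compound 4 is expected to give 5 nM, range 0.8 nM to 30 nM. The estimated step is a 10-fold higher number from compound 3 to compound 4 (1.01 log units; beyond the scatter).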

Compound 4, inhibition constant: 0.54 nM
Compound 4: middle estimate off by 9.3-fold (0.97 log units), on the high side, outside the stated range (below it).
By their numbers in this assay, from the lowest: compound 1; then compounds 3 and 4 (each within the scatter of the next); then compound 2.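

Acetamidomethyl in place of trifluoromethyl at this aromatic carbon gives a 1.1-fold higher number from compound 3 to compound 4 (0.04 log units; within the scatter) in this assay, so the two groups are not told apart here. At this position, a group of more heavy atoms, carrying a hydrogen-bond donor and acceptor, matches trifluoromethyl, whereas ethyl in place of fluoro gave a 330-fold higher number from compound 1 to compound 2 (2.52 log units; beyond the scatter) at a different place on the ring. No measured evidence accounts for this result.

On these data alone, whether an amine, a carboxylic acid or a longer chain at this carbon would also stay within the scatter of compound 3 remains open. The compounds shown also leave open which part of acetamidomethyl, if any, affects the number.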